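Bromo substitution on the fused core across two aryl series

This account rests on a few compounds, and the source may have more. Where it says the series, first, only, none or still open, it means among the compounds named here.

Compound 1 `O=[N+]([O-])c1ccc(Cl)c(/C=C/c2nc3ncccc3[nH]2)c1` in a functional assay on MCF7 cells (Homo sapiens) for antiproliferative activity, read by MTT assay, with a stated time of 72 h (a lower number here means a stronger inhibitor, a higher number a weaker inhibitor), gives 53700 nM. Compound 2 `O=[N+]([O-])c1ccc(Cl)c(/C=C/c2nc3ncc(Br)cc3[nH]2)c1` gives 8810 nM in this assay. The change between them, (bromo in place of hydrogen on an aromatic carbon), produced the step of a 6.1-fold lower number from compound 1 to compound 2 (0.78 log units; beyond the scatter).

Compound 3 `N#Cc1ccc(/C=C/c2nc3ncccc3[nH]2)cc1` gives 12900 nM in this assay. How its core differs from the core of compound 1 is not broken down here. Among the measured compounds shown here, compound 4 `N#Cc1ccc(/C=C/c2nc3ncc(Br)cc3[nH]2)cc1` carries the same change as the one from compound 1 to compound 2, namely (bromo in place of hydrogen on an aromatic carbon); the place is described in the same words in both cases.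

For the measured compounds named here, with only one earlier instance of this change, a step of similar direction but somewhat smaller size is expected, a 3.7-fold lower number from compound 3 to compound 4 (0.57 log units; beyond the scatter), resting on the earlier step of a 6.1-fold lower number from compound 1 to compound 2 (0.78 log units; beyond the scatter). Compound 4 is therefore estimated at 3500 nM in this assay, with an expected range from 1500 nM to 9000 nM.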

Compound 4, half-maximal inhibitory concentration: 7820 nM
Compound 4: middle estimate off by 2.2-fold (0.35 log units), on the low side; measured number inside the range.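

On the nitrile-bearing compounds, bromo in place of hydrogen on an aromatic carbon gives a 1.6-fold lower number from compound 3 to compound 4 (0.22 log units; within the scatter), so no gain can be claimed for compound 4 over compound 3. The size of the step does not carry over from one core to the other in this assay: the same change on two cores in this assay, a 6.1-fold lower number (0.78 log units; beyond the scatter) from compound 1 to compound 2 and a 1.6-fold lower number (0.22 log units; within the scatter) from compound 3 to compound 4, 3.7-fold (0.57 log units) apart, beyond the scatter of two such steps. These two pairs show that the step seen with compound 2 cannot be assumed on another core, but they do not show why the steps differ or whether the difference extends beyond these four compounds.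

Still open, as far as these compounds go, is how a methyl group, a methoxy group or an amine on that same aromatic carbon would behave on each core.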